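Swapping a propyl for a diol on the ring nitrogen

The compounds below may be only part of what the source reports. "The series", "measured", "known", "first", "only" and "open" are said of these compounds alone.

Within the data shown here, compound 2 `CCCn1c(=O)[nH]c2cc(NS(=O)(=O)c3cccc(Cl)c3Cl)c(OC)cc21` stands at the top of the two numbers so far: in a functional assay on CHO cells for antagonist activity at C-C chemokine receptor type 4 (Homo sapiens), read by radioligand binding and GTPgammaS binding (on this read-out higher numbers stand for weaker inhibition and lower numbers for stronger inhibition), compound 2 gives 3980 nM. Compound 1 `COc1cc2[nH]c(=O)[nH]c2cc1NS(=O)(=O)c1cccc(Cl)c1Cl` gives 316 nM in this assay, and the step of a 13-fold higher number from compound 1 to compound 2 (1.10 log units; beyond the scatter) came from putting propyl in place of hydrogen on an aromatic nitrogen. Compound 3 `COc1cc2c(cc1NS(=O)(=O)c1cccc(Cl)c1Cl)[nH]c(=O)n2C(CO)CO` differs from compound 2 by 2-hydroxy-1-(hydroxymethyl)ethyl in place of propyl on an aromatic nitrogen. Among the measured compounds shown here, only that one step bears on this change, and it was large; a diol is not a hydrogen, so the outcome is uncertain. The step of a 2.7-fold lower number from compound 2 to compound 3 (0.42 log units; beyond the scatter) is expected to be modest and downward. For compound 3 the estimate is 1500 nM, within 400 nM to 6000 nM.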

Compound 3, half-maximal inhibitory concentration: 1580 nM
For compound 3 the middle estimate is 1.1-fold (0.02 log units) below the measured one; measured number inside the range.
By their numbers in this assay, from the lowest: compound 1; then compound 3; then compound 2.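

On this ring nitrogen, the 2-hydroxy-1-(hydroxymethyl)ethyl group in place of propyl gives a 2.5-fold lower number from compound 2 to compound 3 (0.40 log units; beyond the scatter) in this assay and so the number depends on the substituent's identity, not merely on the nitrogen carrying one. Against hydrogen the same group still leaves a 5.0-fold higher number from compound 1 to compound 3 (0.70 log units; beyond the scatter) and thus recovers only part of the loss seen with propyl. Nothing shown explains this difference.

On these data alone, whether the hydroxyl groups or the chain's shape drive the shift stays open. A methyl, an amine or a carboxylic acid on this nitrogen would help separate these.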